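The compounds below may be only part of what the source reports. "The series", "measured", "known", "first", "only" and "open" are said of these compounds alone.

In a functional assay on HCT-116 cells (Homo sapiens) for antiproliferative activity, read by MTT assay, with a stated time of 72 h (on this read-out higher numbers stand for weaker inhibition and lower numbers for stronger inhibition), compound 3 `NC1=NC2(CCOCC2)N(OCCCOc2cccc(Cl)c2Cl)C(N)=N1` gives 5 nM, the lowest of the three measured numbers. Compound 1 `NC1=NC2(CCOCC2)N(OCCCOc2cccc(Cl)c2)C(N)=N1` gives 120 nM, and compound 2 `NC1=NC2(CCOCC2)N(OCCCOc2cc(Cl)c(Cl)cc2Cl)C(N)=N1` gives 2750 nM. Compound 4 `NC1=NC2(CCOCC2)N(OCCCOc2ccccc2Cl)C(N)=N1` is not yet measured; it differs from compound 3 by hydrogen in place of chloro on an aromatic carbon. The closest guide is the step of a 24-fold lower number from compound 1 to compound 3 (1.38 log units; beyond the scatter), where a chloro entering on an aromatic carbon brought a large drop; a chloro leaving here points the other way, although it is a different chloro that leaves, and the steps of a 23-fold higher number from compound 1 to compound 2 (1.36 log units; beyond the scatter) and a 550-fold lower number from compound 2 to compound 3 (2.74 log units; beyond the scatter) show that where the chlorines sit changes the numbers a great deal. A higher number is therefore expected in this assay, namely a 12-fold higher number from compound 3 to compound 4 (1.08 log units; beyond the scatter). Compound 4 is estimated at 60 nM, within 15 nM to 250 nM.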

Compound 4, half-maximal inhibitory concentration: 70 nM
Compound 4: the middle estimate sits 1.2-fold (0.07 log units) below what was measured; measured number inside the range.
By their numbers in this assay, from the lowest: compound 3; then compounds 4 and 1 (each within the scatter of the next); then compound 2.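

In this assay, going from 2,3-dichlorophenyl to 2-chlorophenyl gives a 14-fold higher number from compound 3 to compound 4 (1.15 log units; beyond the scatter), so this one chloro, ortho to a chloro group, counts for a great deal on its own. The single chlorine of 2-chlorophenyl and that of 3-chlorophenyl read alike, a 1.7-fold lower number from compound 1 to compound 4 (0.23 log units; within the scatter), so among these compounds the lowest number comes only with 2,3-dichlorophenyl, while 2,4,5-trichlorophenyl stays well apart, a 39-fold lower number from compound 2 to compound 4 (1.59 log units; beyond the scatter). Nothing here gives a reason for these steps. Going by these compounds, whether a fluoro, methyl or methoxy in place of this chloro would keep the low number remains open.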